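Ring Enlargement at the Amine Position of Compound 1

The compounds below may be only part of what the source reports. "The series", "measured", "known", "first", "only" and "open" are said of these compounds alone.

Compound 1 `O=C(CCc1ccc(C(F)(F)F)cc1)Nc1ccc2nc(N3CCC3)ccc2c1` is the stronger of the two compounds measured in an assay on isolated protein for displacement of a labelled ligand from melanin-concentrating hormone receptor 1 (Homo sapiens) (on this read-out lower numbers stand for stronger inhibition and higher numbers for weaker inhibition), where compound 1 gives 4 nM. Among the compounds with values here, its only measured neighbour is compound 2 `NC1CCN(c2ccc3cc(NC(=O)CCc4ccc(C(F)(F)F)cc4)ccc3n2)C1`, which carries 3-aminopyrrolidin-1-yl in place of azetidin-1-yl on an aromatic carbon; in this assay compound 2 gives 12 nM, a step of a 3.0-fold higher number from compound 1 to compound 2 (0.48 log units; beyond the scatter). Compound 3 `O=C(CCc1ccc(C(F)(F)F)cc1)Nc1ccc2nc(N3CCCCCC3)ccc2c1` departs from compound 1 at the same position, with the change (azepan-1-yl in place of azetidin-1-yl on an aromatic carbon). Within the data shown here, the step from compound 1 to compound 2 is the one measurement that bears on this, since it also swaps the azetidin-1-yl for a larger saturated ring at that aromatic carbon, and it cost a modest amount of potency. A still larger ring without the amino group is a different change, so that step is only a loose guide. The account therefore expects a modest weakening for compound 3, of about a 2.3-fold higher number from compound 1 to compound 3 (0.35 log units; beyond the scatter), with a fair chance that it stays within the scatter. Compound 3 is estimated at 9 nM in this assay, within the range 2.5 nM to 35 nM.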

Compound 3, half-maximal inhibitory concentration: 36 nM
Estimate against measurement, compound 3: 4.0-fold (0.60 log units) below, outside the stated range (above it).
By their numbers in this assay, from the lowest: compound 1; then compound 2; then compound 3.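

In this assay, the seven-membered ring taking the place of the four-membered ring at this aromatic carbon gives a 9.0-fold higher number from compound 1 to compound 3 (0.95 log units; beyond the scatter) and so costs more potency than any other change seen at this position. Within the data shown here, the unsubstituted seven-membered ring also falls behind the substituted amine, with azepan-1-yl in place of 3-aminopyrrolidin-1-yl giving a 3.0-fold higher number from compound 2 to compound 3 (0.48 log units; beyond the scatter) and placing azetidin-1-yl, 3-aminopyrrolidin-1-yl and azepan-1-yl in that order across these three compounds, with no compound going against a rise in the number as the ring grows. Nothing shown gives a reason for this order.

Ring size and the amino group change together between compound 2 and the other two compounds, so these three compounds cannot separate the contribution of each. A plain pyrrolidin-1-yl or piperidin-1-yl at the same carbon would give measurements for ring sizes not yet covered here, while a 3-aminoazetidin-1-yl would show what an amine does on the smallest ring.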